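This account rests on a few compounds, and the source may have more. Where it says the series, first, only, none or still open, it means among the compounds named here.

Of the compounds shown here, two have been measured in a functional assay on SNU1 cells (Homo sapiens) for cytotoxicity; on this read-out lower numbers stand for stronger inhibition and higher numbers for weaker inhibition. Compound 1 `C=C1[C@H](O)C[C@H]2C(C)(C)CCC[C@]2(C)[C@H]1/C=C/c1ccoc1` gives 4.8 ug/mL. Compound 2 `CC(=O)O[C@]1(C)CC[C@H]2C(C)(C)CCC[C@]2(C)[C@H]1CC=O`, which carries a different set of groups, gives 4.8 ug/mL in this assay. The two values are level with each other at the digits reported and lie within the usual scatter, so compound 1 stands alongside compound 2 with no difference that can be read from the numbers. Compound 3 `C=C1CC[C@H]2C(C)(C)CCC[C@]2(C)[C@H]1/C=C/c1ccoc1` has not yet been measured in this assay. It differs from compound 1 in one place: hydrogen in place of hydroxy on a saturated ring carbon. Going by the values given here, no measured pair here shows the effect of such a change, so there is no direct guide to its size. The expected step of a 1.4-fold higher number from compound 1 to compound 3 (0.13 log units; within the scatter) is small, if anything a slight shift toward weaker inhibition, and may well stay within the scatter. Compound 3 is therefore expected to give about 6.5 ug/mL, with a range from 2.5 ug/mL to 16 ug/mL.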

Compound 3, half-maximal inhibitory concentration: 8 ug/mL
Estimate against measurement, compound 3: 1.2-fold (0.09 log units) below; the range from low to high includes it.
By their numbers in this assay, from the lowest: compounds 1, 2 and 3 (each within the scatter of the next).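

Going by these compounds alone, the step of a 1.7-fold higher number from compound 1 to compound 3 (0.22 log units; within the scatter) in this assay is the first direct reading of hydrogen in place of hydroxy on this saturated ring carbon. On this one pair, the hydroxy group, with its hydrogen-bond donor and acceptor, can be removed from this position without a difference that stands clear of the usual scatter, so the numbers give no sign that the group is needed for the cytotoxicity seen here. Nothing available explains the size of this step.

As far as these compounds go, whether an amine, a methoxy group or a carbonyl on this ring carbon would move the number beyond the scatter remains open. Also open, from the compounds shown here alone, is whether the same swap would give a similar step on a core other than that of compound 1.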